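The source may hold more compounds than are shown below. What is called first, only, known or untested is meant among the compounds shown, and "the series" means these compounds.

Measured compounds in a functional assay on K562 cells (Homo sapiens) for inhibition; on this read-out lower numbers stand for stronger inhibition of growth and higher numbers for weaker inhibition of growth:
compound 1 `COc1cc(/C=C/C(=O)c2cccc(-n3cc(-c4ccc(Cl)cc4)[nH]c3=O)c2)cc(OC)c1OC` gives 3690 nM
compound 2 `COc1cc(/C=C/C(=O)c2cccc(-n3cc(-c4ccccc4)[nH]c3=O)c2)cc(OC)c1OC` gives 500 nM
compound 3 `COc1ccc(-c2cn(-c3cccc(C(=O)/C=C/c4ccc(O)c(OC)c4)c3)c(=O)[nH]2)cc1` gives 2350 nM

Compound 3 stands second highest of the three numbers in this assay. Its nearest neighbour is compound 1, whose number lies within the scatter of that of compound 3; compound 2 is the furthest, with a lower number beyond the scatter.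

Compound 4 `COc1ccc(-c2cn(-c3cccc(C(=O)/C=C/c4cc(OC)c(OC)c(OC)c4)c3)c(=O)[nH]2)cc1` differs from compound 3 by 3,4,5-trimethoxyphenyl in place of 4-hydroxy-3-methoxyphenyl on a double-bonded chain carbon bound to a double-bonded chain carbon.

Among the compounds with values here, the only measured step, a 7.4-fold lower number from compound 1 to compound 2 (0.87 log units; beyond the scatter), concerns a different place on the shared core and does not bear on this change. Within the data shown here, compound 1 and compound 2 already carry the 3,4,5-trimethoxyphenyl group that enters, and compound 3 carries the 4-hydroxy-3-methoxyphenyl group that leaves, but each of those pairs differs at a second place as well, so no measured step isolates the change. Compound 1 and compound 3 are within the scatter of each other despite differing at both places, which gives no sign of a large effect from this change in this assay. A step of a 1.1-fold higher number from compound 3 to compound 4 (0.03 log units; within the scatter) is therefore expected, none beyond the scatter.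

Compound 4 is estimated at 2500 nM in this assay, with a range from 800 nM to 8000 nM.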

Compound 4, concentration for 50% growth inhibition: 1270 nM
Compound 4: middle estimate off by 2.0-fold (0.29 log units), on the high side; measured number inside the range.
By their numbers in this assay, from the lowest: compound 2; then compounds 4, 3 and 1 (each within the scatter of the next, the first and the last beyond it).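

In this assay the exchange of 4-hydroxy-3-methoxyphenyl for 3,4,5-trimethoxyphenyl on a double-bonded chain carbon bound to a double-bonded chain carbon can now be read on its own: a 1.9-fold lower number from compound 3 to compound 4 (0.27 log units; within the scatter) is the step, so the two groups are not told apart at this place in this series. With 3,4,5-trimethoxyphenyl held fixed, the substituent on the aromatic carbon at the other end now has three members, and methoxy sits apart from both of the others, with a 2.5-fold higher number from compound 2 to compound 4 (0.40 log units; beyond the scatter) and a 2.9-fold lower number from compound 1 to compound 4 (0.46 log units; beyond the scatter) as the steps, giving the order hydrogen, methoxy, chloro from the lowest number to the highest among compound 2, compound 4 and compound 1. No measurement at hand accounts for either the flat chain-end step or this order.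

Open, from the compounds shown here alone, is whether the chain-end step stays as small on the core of compound 2, where the number is lowest. Also open, going by these compounds, is how an amine or a carboxylic acid in place of that hydrogen on the aromatic carbon would compare with hydrogen, methoxy and chloro.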